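Series notes: from compound 3 to compound 4

The compounds below may be only part of what the source reports. "The series", "measured", "known", "first", "only" and "open" are said of these compounds alone.

Compound 3 `Oc1cccc(-c2cc(-c3ccccn3)nc(-c3ccccc3Cl)c2)c1` has no single number in a functional assay on T47D cells (Homo sapiens) for cytotoxicity, read by CCK-8 assay and cell counting, with a stated time of 2 days; a higher number here means a weaker inhibitor, a lower number a stronger inhibitor; its entry is "not determined" (no result reported), no result was reported for it. The neighbouring compounds give some footing: compound 1 `Oc1cccc(-c2cc(-c3cccs3)nc(-c3ccccc3Cl)c2)c1` gives 3990 nM in this assay, and compound 2 `Oc1cccc(-c2cc(-c3ccccc3)nc(-c3ccc(Cl)cc3)c2)c1` gives 11300 nM in this assay. Compound 4 `Oc1cccc(-c2cc(-c3ccccc3)nc(-c3ccccc3Cl)c2)c1` differs from compound 3 by phenyl in place of pyridin-2-yl on an aromatic carbon. Among the measured compounds shown here, no measured step matches this change, so its size is unknown; the expectation for this assay is a shift of modest size in either direction, quite possibly one that stays within the scatter. Compound 4 carries the 2-chlorophenyl group of compound 1 and the phenyl group of compound 2, and those two values bracket a plausible range. Compound 4 is expected to give 6000 nM in this assay, within 2000 nM to 18000 nM.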

Compound 4, half-maximal inhibitory concentration: 2920 nM
For compound 4 the middle estimate is 2.1-fold (0.31 log units) above the measured one; the measured number falls inside the stated range.
By their numbers in this assay, from the lowest: compounds 4 and 1 (each within the scatter of the next); then compound 2.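

In this assay 2-chlorophenyl in place of 4-chlorophenyl gives a 3.9-fold lower number from compound 2 to compound 4 (0.59 log units; beyond the scatter) and so the place of the chlorine on that ring registers in this pair. Phenyl in place of thiophen-2-yl gives a 1.4-fold lower number from compound 1 to compound 4 (0.14 log units; within the scatter) and so this pair does not separate those two rings at this position. The step from compound 3 cannot be read, as compound 3 has no number.

From the compounds shown here alone, whether an amine or a carboxylic acid on the phenyl ring of compound 4 would keep its number remains open. No measurement shown accounts for either step.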